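Cytotoxicity notes on an amide variant of the shared core

This account rests on a few compounds, and the source may have more. Where it says the series, first, only, none or still open, it means among the compounds named here.

Measured so far:
compound 1 `CCOC(=O)CCCNc1ncc(C(Oc2ccc3cc(Br)ccc3c2)c2ccc(Cl)cc2)s1`: "not toxic" (no number reported)
compound 2 `COc1ccc(C(=O)Nc2ncc(C(Oc3ccc4cc(Br)ccc4c3)c3ccc(Cl)cc3)s2)cc1`: > 50000 nM

Compound 2 stands at a limit rather than at a number: in an ADME assay on HepG2 2.2.15 cells (Homo sapiens) for cytotoxicity (a lower number here means that less compound is tolerated, a higher number that more compound is tolerated), compound 2 gives > 50000 nM, which is a limit of the assay only. Compound 1 is entered in this assay as "not toxic" (no number reported), with no number attached. For the measured compounds named here, one of the two entries thus sits at the limit of > 50000 nM in this assay, at which 1 of the 2 values shown sits, and the other carries no number, so no measured step between compounds exists in this assay.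

Compound 3 `N#Cc1cccc(C(=O)Nc2ncc(C(Oc3ccc4cc(Br)ccc4c3)c3ccc(Cl)cc3)s2)c1` differs from compound 2 by 3-cyanophenyl in place of 4-methoxyphenyl on a carbonyl carbon. With nothing measured to lean on, no shift beyond the usual scatter is expected from this change, and the expected step is a step that the limit leaves unreadable from compound 2 to compound 3. Compound 3 is therefore estimated at 60000 nM in this assay, with a range from 25000 nM to 150000 nM, and it is expected most likely to be reported again only as a limit.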

Compound 3, half-maximal cytotoxic concentration: > 50000 nM
Compound 3 was reported as a limit; the forecaster's own chance of this, stated with the estimate: 75%; the middle value does not contradict the limit.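

No step can be read from compound 2 to compound 3 in this assay, since both are reported only as limits: the limit of > 50000 nM in this assay, at which 2 of the 3 values shown sit.

The compounds shown leave open whether 3-cyanophenyl and 4-methoxyphenyl differ at all in half-maximal cytotoxic concentration, and where any of the three compounds would give an actual number.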